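The compounds below may be only part of what the source reports. "The series", "measured", "known", "first", "only" and "open" are said of these compounds alone.

For the measured compounds named here, in a functional assay on MCF7 cells (Homo sapiens) for antiproliferative activity (a higher number here means a weaker inhibitor, a lower number a stronger inhibitor), compound 1 `CCCCn1c(Cc2cc(OC)c(OC)c(OC)c2)nc2c(N)nc(F)nc21` gives 24000 nM, the lowest of the three numbers measured so far. Compound 2 `CC/C=C\Cn1c(Cc2cc(OC)c(OC)c(OC)c2)nc2c(N)ncnc21` gives 64600 nM in this assay, and compound 3 `COc1cc(Cc2nc3c(N)ncnc3n2CC2CC2)cc(OC)c1OC` gives 75900 nM. Compound 1 differs from compound 2 in two places, so only the two values themselves can be set side by side; compound 1 stands beyond the scatter from both compound 2 and compound 3. Between compound 2 and compound 3 only the chain on the aromatic nitrogen changes: a 1.2-fold higher number from compound 2 to compound 3 (0.07 log units; within the scatter), a step that stays within the scatter.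

Compound 4 `COCCn1c(Cc2cc(OC)c(OC)c(OC)c2)nc2c(N)nc(F)nc21` keeps the core of compound 1 and alters the chain on the aromatic nitrogen: methoxy in place of ethyl on a saturated chain carbon, two bonds along the chain from an aromatic nitrogen. Going by the values given here, the one measured step that bears on this, the change of chain from compound 2 to compound 3, left the number essentially where it was. That step exchanged one hydrocarbon chain for another, while here methoxy takes the place of ethyl, so the precedent is only partial. On this basis compound 4 is expected to stay close to compound 1, with a 1.3-fold higher number from compound 1 to compound 4 (0.10 log units; within the scatter) as the estimated step, not beyond what the scatter allows. For compound 4 the estimated value in this assay is 30000 nM, with a range from 10000 nM to 90000 nM.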

Compound 4, half-maximal inhibitory concentration: 64600 nM
Compound 4: middle estimate off by 2.2-fold (0.33 log units), on the low side, and the stated range covers the measured number.
By their numbers in this assay, from the lowest: compound 1; then compounds 2, 4 and 3 (each within the scatter of the next).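

In this assay, the exchange of ethyl for methoxy on a saturated chain carbon, two bonds along the chain from an aromatic nitrogen, gives a 2.7-fold higher number from compound 1 to compound 4 (0.43 log units; beyond the scatter), a modest step but the first at this chain to pass beyond the scatter. The earlier step on this chain swapped one hydrocarbon group for another on a different core and left the number in place, whereas butyl to 2-methoxyethyl, which puts one oxygen and one hydrogen-bond acceptor into a chain of unchanged heavy-atom count, weakens inhibition of this antiproliferative read-out, so the position does not tolerate every change of chain. Nothing shown explains why this exchange raises the number, and no measurement on the compounds bears on a cause.

The compounds shown leave open whether the rise follows the oxygen itself, since a hydroxyl or an amine on the same saturated chain carbon would test that, and whether a longer chain carrying methoxy behaves alike. They also leave open whether the same exchange gives a step of this size on the core of compound 2.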